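A few compounds are considered here, and "the series" means these few. Any claim that something is new, unique, unknown or untested is made for them only; others in the source may bear on it.

Measured compounds:
Compound 1 `COc1cc(C)cc(-c2c(-c3ccnc(-c4ccc(N(C)C)cc4)c3)cnn2CC#N)c1` — 6%
Compound 2 `COc1cc(C)cc(-c2nn(CC#N)cc2-c2ccnc(-c3ccc(N(C)C)cc3)c2)c1` — 16%
Compound 3 `COc1cc(C)cc(-c2nn(CC#N)cc2-c2ccc(-c3cccc(C(C)=O)c3)nc2)c1` — 13%

All three were tested in a functional assay on CCRF-CEM cells (Homo sapiens) for cytotoxicity, read by sulforhodamine B assay, with a stated time of 48 h, tested at 1 uM; on this read-out lower numbers stand for a stronger effect and higher numbers for a weaker effect at the one concentration tested. Compound 1 gives 6%, compound 3 gives 13% and compound 2 gives 16%. Compound 2 shows the highest of the three numbers, but its nearest neighbour, compound 3, lies within the scatter of it, and so does the furthest one, compound 1. On these numbers, then, the three compounds cannot be told apart: each of them leaves only a small fraction of the cells' growth intact at this concentration.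

The next compound, compound 4 `Cc1cc(O)cc(-c2nn(CC#N)cc2-c2ccnc(-c3ccc(N(C)C)cc3)c2)c1`, is compound 2 with one change: hydrogen in place of methyl on an oxygen on an aromatic ring. Going by the values given here, no measured pair shows what this change does in this assay, so there is no step to lean on. Since compound 2 already sits at 16% and the change is a single carbon, the expected step is a number 4 percentage points higher from compound 2 to compound 4 (within the scatter), small and within the scatter. The value expected for compound 4 is therefore 20%, with a range from 8% to 40%.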

Compound 4, a percentage reported as activity, at one concentration (the size of the read-out at that concentration, not a potency): 13%
Beside the measured number, compound 4's estimate is 7 percentage points above it; low and high end bracket the measured number.
By their numbers in this assay, from the lowest: compounds 1, 3, 4 and 2 (each within the scatter of the next).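

In this assay, going by these compounds alone, replacing methoxy with hydroxy on the aromatic ring gives a number 3 percentage points lower from compound 2 to compound 4 (within the scatter), the first step that isolates a single change in this set. At this one concentration, then, the methyl on that oxygen can be removed without a difference that can be told from the scatter, and the free hydroxy fits the same small range of numbers as the methoxy. No measurement shown here helps to explain this result.

A single pair at a single concentration cannot show whether the two compounds would separate at other concentrations. Going by these compounds, it also remains open how an amine or a longer chain such as ethoxy would read in place of the methoxy.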